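Amide variation on the shared core: a weak antiproliferative series

A few compounds are considered here, and "the series" means these few. Any claim that something is new, unique, unknown or untested is made for them only; others in the source may bear on it.

Measured compounds:
- compound 1 `O=C(Nc1ccc(Cl)c(-c2nnc3c(Cl)cccn23)c1)c1ccc(F)cc1Cl`: 75000 nM
- compound 2 `Cc1cc(Cl)ccc1C(=O)Nc1ccc(Cl)c(-c2nnc3c(Cl)cccn23)c1`: > 100000 nM, which is a limit of the assay and not a number
- compound 3 `O=C(Nc1ccc(Cl)c(-c2nnc3c(Cl)cccn23)c1)c1ccon1`: > 100000 nM, which is a limit of the assay and not a number

For the measured compounds named here, in a functional assay on MDA-MB-231 cells (Homo sapiens) for antiproliferative activity, read by MTT assay, with stated times of 72 h and 4 h (on this read-out higher numbers stand for weaker inhibition and lower numbers for stronger inhibition), compound 1 is the only compound that gives a number at all; the other two values shown are limits. Evidence on the measured steps comes from the limit of > 100000 nM in this assay, at which 2 of the 3 values shown sit. The step of an at least 1.3-fold higher number from compound 1 to compound 2 (0.12 log units; that floor lies within the scatter) and the step of an at least 1.3-fold higher number from compound 1 to compound 3 (0.12 log units; that floor lies within the scatter) are each read only to a floor, and that floor lies within the scatter. The step that the two limits leave unreadable from compound 2 to compound 3 cannot be read.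

Compound 4 `O=C(Nc1ccc(Cl)c(-c2nnc3c(Cl)cccn23)c1)c1ccccc1` is not yet measured. Relative to compound 1 the change is phenyl in place of 2-chloro-4-fluorophenyl on a carbonyl carbon. Both measured steps that bear on it also replace the 2-chloro-4-fluorophenyl group on the carbonyl carbon, and each leads from compound 1 to a limit rather than to a lower number. On that basis the change from compound 1 to compound 4 is expected to give a step of about a 1.5-fold higher number from compound 1 to compound 4 (0.17 log units; within the scatter) in this assay, towards a weaker inhibition, with a fair chance that only a limit is reported. The estimate for compound 4 in this assay is 110000 nM, expected to fall between 50000 nM and 250000 nM.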

Compound 4, half-maximal inhibitory concentration: 58200 nM
Compound 4: the middle estimate sits 1.9-fold (0.28 log units) above what was measured; low and high end bracket the measured number.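

In this assay, phenyl in place of 2-chloro-4-fluorophenyl on a carbonyl carbon gives a 1.3-fold lower number from compound 1 to compound 4 (0.11 log units; within the scatter), so a number can still be read at this position without the chlorine and fluorine of compound 1. Against the two compounds that sit at a limit, the readings are an at least 1.7-fold lower number from compound 3 to compound 4 (0.23 log units; that floor lies within the scatter) and an at least 1.7-fold lower number from compound 2 to compound 4 (0.23 log units; that floor lies within the scatter); both floors lie within the scatter, so neither 1,2-oxazol-3-yl nor 4-chloro-2-methylphenyl can yet be separated from phenyl. No step at this position is read beyond the scatter, and the step between compound 2 and compound 3 cannot be read, so the comparisons remain bounded by the assay limit: the limit of > 100000 nM in this assay, at which 2 of the 4 values shown sit.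

On these data alone, how a saturated amine, a carboxylic acid or a longer alkyl chain on the carbonyl carbon would read in this assay stays open, as does whether any group in that place gives a step beyond the scatter. Also open, as far as these compounds go, is whether phenyl carrying only the chlorine or only the fluorine of compound 1 would read alongside compound 1 and compound 4.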